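Moving the acid further along the sulfanyl chain

The compounds below may be only part of what the source reports. "The series", "measured", "known", "first", "only" and "open" are said of these compounds alone.

Compound 1 `CCCCCCOc1cc(-c2ccccc2)c(-c2ccccc2)nn1` and compound 2 `CCCCCCSc1cc(-c2ccccc2)c(-c2ccccc2)nn1` share one core and differ only in the link that holds the hexyl chain. In an assay on microsomes from liver for inhibition of sterol O-acyltransferase 1 (Rattus norvegicus) (on this read-out lower numbers stand for stronger inhibition and higher numbers for weaker inhibition), compound 1 gives 72000 nM, and compound 2 gives 62000 nM; the step of a 1.2-fold lower number from compound 1 to compound 2 (0.06 log units; within the scatter) sits within the scatter. Compound 3 `O=C(O)CCCCCSc1cc(-c2ccccc2)c(-c2ccccc2)nn1` carries a carboxy group at the far end of that chain. In this assay compound 3 reaches only the limit of the assay, > 300000 nM, so where it stands is known only as a range (the limit of > 300000 nM in this assay, at which 1 of the 3 values shown sits). The step of an at least 4.1-fold higher number from compound 1 to compound 3 (0.61 log units; beyond the scatter) and the step of an at least 4.8-fold higher number from compound 2 to compound 3 (0.68 log units; beyond the scatter) both go toward weaker inhibition and both lie beyond the scatter. Compound 4 `O=C(O)CCCCCCCSc1cc(-c2ccccc2)c(-c2ccccc2)nn1` is the next member of the series, with 2-carboxyethyl in place of carboxy on a saturated chain carbon, five bonds along the chain from a sulfur. Within the data shown here, no measured step shows what carrying the acid further out does; the two steps that bear on it, from compounds 1 and 2 to compound 3, show that the acid-bearing chain ended at the limit. Compound 4 is therefore expected to stay weak, with a step of a number no higher from compound 3 to compound 4 (the limit leaves the size open) that is expected to remain within the scatter. The estimate for compound 4 in this assay is 300000 nM, expected between 100000 nM and 1000000 nM, and most likely reported again only as a limit.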

Compound 4, half-maximal inhibitory concentration: > 300000 nM
Compound 4: no number, only a limit; the forecaster's own chance of this, stated with the estimate: 65%; the middle value sits exactly at the limit.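

In this assay compound 4 also gives only a limit of the assay, > 300000 nM, and not a number. Measured against the hexyl chain without the acid, the result is an at least 4.8-fold higher number from compound 2 to compound 4 (0.68 log units; beyond the scatter), so weak inhibition with a carboxy group at the chain end now holds at a second chain length and not only in compound 3. The step from compound 3 to compound 4 cannot be read, because both values are limits and neither gives a position on the scale: the limit of > 300000 nM in this assay, at which 2 of the 4 values shown sit.

From the compounds shown here alone, how far past the limit compound 3 and compound 4 lie remains unknown, which leaves open whether 2-carboxyethyl in place of carboxy changes inhibition at all. Also open, going by these compounds, is whether a methyl ester, a primary amide, a hydroxy group or an amine at the same chain end would bring the read-out back to a measurable number, and how a longer chain with no acid would compare with compound 2.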